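This account rests on a few compounds, and the source may have more. Where it says the series, first, only, none or still open, it means among the compounds named here.

compound 1 `CC/C=C/C(=O)Nc1cccc(Oc2nc(Nc3cccc(C#N)c3)nc3c2CSCC3)c1`: 15900 nM
compound 2 `CC(C)=CC(=O)Nc1cccc(Oc2nc(Nc3cccc(C#N)c3)nc3c2CSCC3)c1`: > 50000 nM (a limit)

Within the data shown here, in a functional assay on MCF7 cells (Homo sapiens) for antiproliferative activity, read by MTT assay, with a stated time of 72 h (on this read-out higher numbers stand for weaker inhibition and lower numbers for stronger inhibition), compound 1 stands at 15900 nM as the only actual number so far. Compound 3 `CC/C=C/C(=O)Nc1cccc(Oc2nc(Nc3ccc(OC)cc3)nc3c2CSCC3)c1` has 4-methoxyphenyl in place of 3-cyanophenyl on a nitrogen on an aromatic ring. Among the measured compounds shown here, the single measured step lies on a carbonyl carbon instead (an at least 3.1-fold higher number from compound 1 to compound 2 (0.49 log units; beyond the scatter)). It bears only indirectly and gives no direction for this change. The expected result is no shift beyond the scatter (a 1.1-fold higher number from compound 1 to compound 3 (0.05 log units; within the scatter)). For compound 3 the estimated value in this assay is 18000 nM with an expected range of 5000 nM to 50000 nM in that read-out.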

Compound 3, half-maximal inhibitory concentration: 31400 nM
Compound 3: the middle estimate sits 1.7-fold (0.24 log units) below what was measured; measured number inside the range.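

In this assay, among these compounds, the only step at this position reads a 2.0-fold higher number from compound 1 to compound 3 (0.30 log units; within the scatter), so on the nitrogen 4-methoxyphenyl and 3-cyanophenyl cannot be told apart, although the nitrile is gone and the ring substitution differs. Unlike the step on the carbonyl carbon, this change leaves a measurable number in place. Nothing shown gives a cause for this step.

Still open, as far as these compounds go, is whether a carboxylic acid or an amine on this phenyl ring would move the number beyond the scatter. From the compounds shown here alone, the separate contributions of group identity and ring position also remain open, as a 3-methoxyphenyl group would be needed to separate them.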